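The source may report more compounds than this note shows. Statements on the series, on what has been measured and on what is new or still open speak of the compounds shown alone.

In a functional assay on SK-BR-3 cells (Homo sapiens) for antiproliferative activity, read by MTT assay, with a stated time of 72 h (a higher number here means a weaker inhibitor, a lower number a stronger inhibitor), compound 1 `C/C=C1/[C@H](O[C@@H]2O[C@H](CO)[C@@H](O)[C@H](O)[C@H]2O)OC=C(C(=O)OC)[C@H]1CC(=O)OCCc1ccc(OC)c(OC)c1` gives > 15000 nM, which is a limit of the assay rather than a measured number, so compound 1 sits at the weak edge of what this assay can resolve. Compound 2 `C/C=C1/[C@H](O[C@@H]2O[C@H](COC(C)=O)[C@@H](OC(C)=O)[C@H](OC(C)=O)[C@H]2OC(C)=O)OC=C(C(=O)OC)[C@H]1CC(=O)OCCC(C)C`, built on the same core but with a different sugar and a different ester tail, gives > 15000 nM in this assay, again only a limit. Among the compounds with values here, both results thus rest at the same point, (the limit of > 15000 nM in this assay, at which 2 of the 2 values shown sit), and no step between measured compounds can be drawn from them.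

Compound 3 `C/C=C1/[C@H](O[C@@H]2O[C@H](CO)[C@@H](O)[C@H](O)[C@H]2O)OC=C(C(=O)OC)[C@H]1CC(=O)OCCC` keeps the free sugar of compound 1 and differs from it in one place: methyl in place of 3,4-dimethoxyphenyl on a saturated chain carbon, two bonds along the chain from an oxygen next to a carbonyl group. The change strips a large aromatic group from the ester tail and leaves a short chain.

Compound 1 shows only the limit > 15000 nM. Compound 2, with its own different tail, likewise shows only the limit > 15000 nM. Nothing in these values suggests that a shorter tail would bring activity into range. Compound 3 is therefore expected to show essentially no change, a step that the limit leaves unreadable from compound 1 to compound 3, and most likely to be reported again as a limit. The estimate for compound 3 is 25000 nM, within 10000 nM to 80000 nM.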

Compound 3, half-maximal inhibitory concentration: > 15000 nM
Compound 3 was reported as a limit (the forecaster's own chance of this, stated with the estimate: 85%); the middle value lies beyond the limit too.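

Within the data shown here, compound 1 and compound 3 both rest at a limit of the assay rather than at a number, so no step between them can be read: (the limit of > 15000 nM in this assay, at which 3 of the 3 values shown sit). The compounds shown leave open whether any change to the sugar or the ester tail of the shared core can bring a result within the range of this assay at all.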